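Notes on a fused bicyclic series, inhibition in whole organism

A few compounds are considered here, and "the series" means these few. Any claim that something is new, unique, unknown or untested is made for them only; others in the source may bear on it.

Measured so far:
compound 1, `Cc1nc(C)n2c(=O)n(C)ncc12`, > 48000 nM
compound 2, `CCCc1nc(C)c2cnn(C)c(=O)n12`, 20000 nM
compound 3, `CCCc1nc(C)c2ccnc(Nc3cc[nH]n3)n12`, 25000 nM

All three were run in a functional assay for inhibition, with Homo sapiens as the target; on this read-out lower numbers stand for stronger inhibition and higher numbers for weaker inhibition. For compound 1 the reading is a limit of the assay and not a number: the limit of > 48000 nM in this assay, at which 1 of the 3 values shown sits. In this assay compound 2 gives 20000 nM. The two differ in one place, (hydrogen in place of ethyl on a saturated chain carbon bound to an aromatic carbon), and the step of an at least 2.4-fold higher number from compound 2 to compound 1 (0.38 log units; beyond the scatter) is at least modest. Compound 3 carries a different core; how the two cores differ is not broken down here. In this assay compound 3 gives 25000 nM, which sits within the scatter of the value of compound 2.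

Compound 4, `Cc1nc(C)n2c(Nc3cc[nH]n3)nccc12`, is the not yet measured partner of compound 3, reached by the same change, (hydrogen in place of ethyl on a saturated chain carbon bound to an aromatic carbon), at the same place as before. The step from compound 3 to compound 4 is expected to be a 2.4-fold higher number from compound 3 to compound 4 (0.38 log units; beyond the scatter) because the matched pair shows an at least 2.4-fold higher number from compound 2 to compound 1 (0.38 log units; beyond the scatter). On this basis compound 4 is expected to give about 60000 nM, with a range from 25000 nM to 150000 nM, so a limit reading is the likelier outcome.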

Compound 4, half-maximal inhibitory concentration: 53000 nM
Compound 4: the middle estimate sits 1.1-fold (0.05 log units) above what was measured; low and high end bracket the measured number.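

In this assay, going from propyl to methyl, which puts hydrogen in place of ethyl on a saturated chain carbon bound to an aromatic carbon, gives a 2.1-fold higher number from compound 3 to compound 4 (0.33 log units; beyond the scatter), so the weaker inhibition seen with this change on the core of compound 2 appears on the core of compound 3 as well. Set side by side, the two steps point the same way: the same change on two cores in this assay, an at least 2.4-fold higher number (0.38 log units; beyond the scatter) from compound 2 to compound 1 and a 2.1-fold higher number (0.33 log units; beyond the scatter) from compound 3 to compound 4; the limit leaves it open whether they differ

This is a shared direction on two cores only; it does not establish that the change has the same size on both, and it says nothing about how the change would behave on any further core.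

On these data alone, what a longer chain such as butyl, or an amine or a carboxylic acid carried on the chain, would do at the same place remains open on both cores. Also open, as far as these compounds go, is how far the difference between the two cores itself matters, as compound 2 and compound 3 differ in more than one place.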